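Back toward a methoxy-bearing ring on the amide

The compounds below may be only part of what the source reports. "The series", "measured", "known", "first", "only" and "open" are said of these compounds alone.

Measured so far:
Compound 1, `CCN(CC)S(=O)(=O)c1ccc(S(=O)(=O)N2CCC[C@@H](C(=O)N3CCC(OC)CC3)C2)cc1`, gives 50 nM in a functional assay on MIA PaCa-2 cells (Homo sapiens) for inhibition, read by MTT assay, with a stated time of 3 days; a higher number here means a weaker inhibitor, a lower number a stronger inhibitor.
Compound 2, `CCN(CC)S(=O)(=O)c1ccc(S(=O)(=O)N2CCC[C@@H](C(=O)N3CCS(=O)(=O)CC3)C2)cc1`, gives 220 nM in this assay.

Compound 2 shows the highest of the two numbers. Among the compounds with values here, its only neighbour lies one step away: a 4.4-fold higher number from compound 1 to compound 2 (0.64 log units; beyond the scatter), a modest change that exceeds the usual scatter. Compound 3, `CCN(CC)S(=O)(=O)c1ccc(S(=O)(=O)N2CCC[C@@H](C(=O)N3CC[C@@H](OC)C3)C2)cc1`, is not yet measured. It differs from compound 2 by 3-methoxypyrrolidin-1-yl in place of 1,1-dioxothiomorpholin-4-yl on a carbonyl carbon. Within the data shown here, only one measured step bears on this change, the one in which 1,1-dioxothiomorpholin-4-yl replaced 4-methoxypiperidin-1-yl and the number rose. Compound 3 restores a methoxy-bearing saturated ring, though a five-membered one, so the step of a 3.1-fold lower number from compound 2 to compound 3 (0.50 log units; beyond the scatter) is expected to run in the opposite direction, back toward lower numbers. The value of compound 3 in this assay is expected to be about 70 nM, within a range from 30 nM to 200 nM.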

Compound 3, half-maximal inhibitory concentration: 1070 nM
Beside the measured number, compound 3's estimate is 15-fold (1.18 log units) below it, outside the stated range (above it).
By their numbers in this assay, from the lowest: compound 1; then compound 2; then compound 3.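

In this assay, a methoxy group on the ring does not by itself bring the number back down. Replacing 4-methoxypiperidin-1-yl with 3-methoxypyrrolidin-1-yl on the carbonyl carbon gives a 21-fold higher number from compound 1 to compound 3 (1.33 log units; beyond the scatter) as a large loss, and replacing 1,1-dioxothiomorpholin-4-yl gives a 4.9-fold higher number from compound 2 to compound 3 (0.69 log units; beyond the scatter) as a further rise, so a methoxy-bearing ring now supplies both the lowest and the highest number of the three. The data shown offer no measured explanation for this order.

Between compound 1 and compound 3, ring size, the place of the methoxy group and the defined stereocentre all change together, so their contributions cannot be separated. As far as these compounds go, a plain pyrrolidin-1-yl, a 3-methoxypiperidin-1-yl or the opposite stereoisomer of 3-methoxypyrrolidin-1-yl would each help pull these apart, and how they read remains open.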